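Pyridin-2-yl for phenyl on the cyclopropane of compound 1

The source may hold more compounds than are shown below. What is called first, only, known or untested is meant among the compounds shown, and "the series" means these compounds.

Compound 1 `CC[C@H](C)[C@H](N)CN(C(=O)[C@@H]1C[C@H]1c1ccccc1)c1ccc(-c2ccc(COC)cc2)cc1` carries a 2-phenylcyclopropyl group on the amide carbonyl and a methoxymethyl group on the distal aromatic ring. Among the measured compounds shown here, in a functional assay for agonist activity at G protein-coupled receptor 88 (Homo sapiens), read by HTRF and cAMP accumulation (a higher number here means that more compound is needed for the effect, a lower number that less compound is needed), compound 1 gives 35 nM, the lowest number of the three measured so far. Compound 2 `CCOC(=O)c1ccc(-c2ccc(N(C[C@@H](N)[C@@H](C)CC)C(=O)[C@@H]3C[C@H]3c3ccccc3)cc2)cc1` gives 260 nM in this assay, and compound 3 `CC[C@H](C)[C@H](N)CN(C(=O)[C@@H]1C[C@H]1c1ccccc1)c1ccc(-c2ccc(N)cc2)cc1` gives 320 nM. The step of a 7.4-fold higher number from compound 1 to compound 2 (0.87 log units; beyond the scatter) and the step of a 9.1-fold higher number from compound 1 to compound 3 (0.96 log units; beyond the scatter) both run in the same direction; between the two variants, the step of a 1.2-fold higher number from compound 2 to compound 3 (0.09 log units; within the scatter) shows no separation.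

Compound 4 `CC[C@H](C)[C@H](N)CN(C(=O)[C@H]1C[C@@H]1c1ccccn1)c1ccc(-c2ccc(COC)cc2)cc1` is the unmeasured case, and it differs from compound 1 at a place left untouched by the other two: 2-(pyridin-2-yl)cyclopropyl in place of 2-phenylcyclopropyl on a carbonyl carbon. Every measured step in the series concerns the substituent on the distal aromatic ring, so none of them speaks directly to an exchange on the cyclopropane. What they do show is that the shared core of compound 1 tolerates changes at one end without collapse, with modest steps at worst. For compound 4 the expectation is therefore a small step, a 1.7-fold higher number from compound 1 to compound 4 (0.23 log units; within the scatter), with the number estimated at 60 nM and a range from 15 nM to 250 nM.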

Compound 4, half-maximal effective concentration: 1200 nM
Beside the measured number, compound 4's estimate is 20-fold (1.30 log units) below it; measured number outside the range, above it.
By their numbers in this assay, from the lowest: compound 1; then compounds 2 and 3 (each within the scatter of the next); then compound 4.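

In this assay, among the compounds shown here, the exchange of 2-phenylcyclopropyl for 2-(pyridin-2-yl)cyclopropyl on a carbonyl carbon gives a 34-fold higher number from compound 1 to compound 4 (1.54 log units; beyond the scatter), the only step read at this position and a larger one than either exchange on an aromatic carbon, a 7.4-fold higher number from compound 1 to compound 2 (0.87 log units; beyond the scatter) and a 9.1-fold higher number from compound 1 to compound 3 (0.96 log units; beyond the scatter). The change is small by count, with 9 heavy atoms leaving and 9 entering, one ring carbon replaced by nitrogen and one hydrogen-bond acceptor gained, so the tolerance seen on the aromatic carbon does not extend to this position. Nothing available bears on what lies behind the size of this step.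

Still open, from the compounds shown here alone, is whether 2-(pyridin-3-yl)cyclopropyl, 2-(pyridin-4-yl)cyclopropyl or 2-(4-fluorophenyl)cyclopropyl on the same carbonyl carbon would stand nearer compound 1 or nearer compound 4 in this assay. Also open, going by these compounds, is whether the same exchange on the cyclopropane gives a step of similar size when ethoxycarbonyl or amino replaces methoxymethyl on the aromatic carbon.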